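A few compounds are considered here, and "the series" means these few. Any claim that something is new, unique, unknown or untested is made for them only; others in the source may bear on it.

In an ADME assay on GES1 cells (Homo sapiens) for inhibition, read by MTT assay, with a stated time of 72 h (on this read-out higher numbers stand for weaker inhibition and lower numbers for stronger inhibition), compound 1 (`Cc1cc(Nc2cc(-c3ccccc3)[nH]n2)n2nc(SCc3ccc(F)cc3)nc2n1`) reads 35500 nM and compound 2 (`Cc1cc(Nc2cc(-c3ccccc3)[nH]n2)n2nc(SCc3ccccc3Br)nc2n1`) reads 41100 nM, while compound 3 (`Cc1cc(Nc2cc(-c3ccccc3)[nH]n2)n2nc(SCCCc3ccccc3)nc2n1`) has 40200 nM as its reading. Compound 3 thus sits level with the other two, within the scatter of both. Compound 4 (`C=CCSc1nc2nc(C)cc(Nc3cc(-c4ccccc4)[nH]n3)n2n1`) differs from it at one place: vinyl in place of phenethyl on a saturated chain carbon bound to a sulfur. Three measured steps at that place bear on this change (a 1.2-fold higher number from compound 1 to compound 2 (0.06 log units; within the scatter); a 1.1-fold higher number from compound 1 to compound 3 (0.05 log units; within the scatter); a 1.0-fold lower number from compound 2 to compound 3 (0.01 log units; within the scatter)), and all stay within the scatter. On these data alone, each measured compound keeps an aromatic ring there, so losing the ring is untested, and no step beyond the scatter is expected. The expected change (a 1.0-fold higher number from compound 3 to compound 4 (0.02 log units; within the scatter)) is therefore small. The estimate for compound 4 is 42000 nM (range 24000 nM to 75000 nM).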

Compound 4, half-maximal inhibitory concentration: > 50000 nM
Compound 4 ended at the assay's limit; the forecaster's own chance of this, stated with the estimate: 10%; middle value at least 1.1-fold (0.07 log units) away from the limit.
By their numbers in this assay, from the lowest: compounds 1, 3 and 2 (each within the scatter of the next). At a limit, above all of these: compound 4.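

With allyl in place of the ring-bearing groups on a saturated chain carbon bound to a sulfur, compound 4 has no ring at this place, and its reading in this assay is a limit, not a number: the limit of > 50000 nM in this assay, at which 1 of the 4 values shown sits. Losing the ring brought no stronger inhibition here. Yet an at least 1.2-fold higher number from compound 3 to compound 4 (0.09 log units; that floor lies within the scatter) and an at least 1.2-fold higher number from compound 2 to compound 4 (0.08 log units; that floor lies within the scatter) and an at least 1.4-fold higher number from compound 1 to compound 4 (0.14 log units; that floor lies within the scatter) are only floors, so the true size of the rise remains unknown.

On these data alone, whether a saturated propyl chain would read like allyl remains open, so the loss of the ring cannot be separated from the double bond. As far as these compounds go, how an amine or a carboxylic acid at this place would read also remains open.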